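Methylating the Ring Amide Nitrogen of Compound 3

This account rests on a few compounds, and the source may have more. Where it says the series, first, only, none or still open, it means among the compounds named here.

Three spiro compounds were tested in a functional assay on the whole organism (strain Wister albino) for inhibition, with Rattus norvegicus as the target, read by paw edema, with stated times of 1 h and 2 h, at a dose of 50 mg/kg by the intraperitoneal route; a lower number here means less inhibition, a higher number more inhibition at the dose given (going by the name of the read-out). Compound 1 `CN1C/C(=C\c2ccccc2)C(=O)[C@]2(C1)[C@@H](c1ccccc1)CN(C)[C@@]21C(=O)Nc2ccccc21` gives 73.3%, compound 2 `CN1C/C(=C\c2ccc(Br)cc2)C(=O)[C@]2(C1)[C@@H](c1ccc(Br)cc1)CN(C)[C@@]21C(=O)Nc2ccccc21` gives 69.3%, and compound 3 `Cc1ccc(/C=C2\CN(C)C[C@@]3(C2=O)[C@@H](c2ccc(C)cc2)CN(C)[C@@]32C(=O)Nc3ccccc32)cc1` gives 52.1%, the lowest of the three numbers, lying further from compound 2 and compound 1 than the usual scatter. Compound 4 `Cc1ccc(/C=C2\CN(C)C[C@@]3(C2=O)[C@@H](c2ccc(C)cc2)CN(C)[C@@]32C(=O)N(C)c3ccccc32)cc1` is the unmeasured partner of compound 3. Among the measured compounds shown here, the single change is methyl in place of hydrogen on an amide-type nitrogen in a ring. For the measured compounds named here, no pair of measured compounds differs by such a change, so no measured step is available for guidance. From compound 3 to compound 4, only a small step in either direction, or none beyond the scatter, is expected in this assay. The expected value for compound 4 is 50%, with a likely range from 35% to 65%. This estimate means a step of a number 2.1 percentage points lower from compound 3 to compound 4 (within the scatter).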

Compound 4, a percentage reported as inhibition, in the whole organism at one dose (the size of the read-out at that dose, not a potency): 62%
The estimate for compound 4 lay 12 percentage points below the measured number; the measured number falls inside the stated range.
By their numbers in this assay, from the lowest: compounds 3, 4, 2 and 1 (each within the scatter of the next, the first and the last beyond it).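

In this assay, methyl in place of hydrogen on the amide-type nitrogen in a ring gives a step of a number 9.9 percentage points higher from compound 3 to compound 4 (within the scatter). Among the compounds shown here, compounds 1, 2 and 3 all carry the amide hydrogen, so this is the first reading at this position, and it shows that in this one pair the read-out persists at the dose given without that hydrogen. Nothing measured here gives a reason for the size of this step.

From the compounds shown here alone, whether a longer chain such as propyl or a benzyl group would be accepted on this nitrogen remains open. So does whether methyl there would give a similar step from compound 1 or compound 2.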